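Swapping a fluorine for a nitrile on the hydrazide

The source may hold more compounds than are shown below. What is called first, only, known or untested is meant among the compounds shown, and "the series" means these compounds.

Measured compounds:
compound 1 `COc1ccccc1C(=O)N(NC(=O)c1ccccc1)C(C)(C)C`: 525 nM
compound 2 `CC(C)(C)N(NC(=O)c1ccccc1F)C(=O)c1ccccc1Cl`: 51.3 nM

In an assay on cells for agonist activity at ecdysone receptor (Bombyx mori), read by a luciferase reporter, with a stated time of 24 h (on this read-out lower numbers stand for an effect already at smaller amounts and higher numbers for an effect only at larger amounts of compound), compound 1 gives 525 nM. Compound 2 gives 51.3 nM, the lowest of the two numbers, and the gap to compound 1 lies beyond the usual scatter. Compound 3 `CC(C)(C)N(NC(=O)c1cccc(C#N)c1)C(=O)c1ccccc1Cl` has not yet been measured. It differs from compound 2 by 3-cyanophenyl in place of 2-fluorophenyl on a carbonyl carbon. Going by the values given here, no measured pair shows a change of this kind, so nothing is known about its size. The step of a 1.6-fold higher number from compound 2 to compound 3 (0.19 log units; within the scatter) is expected to be small, within or only just beyond the scatter. Compound 3 is therefore estimated at 80 nM, with a range from 20 nM to 400 nM.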

Compound 3, half-maximal effective concentration: 955 nM
Beside the measured number, compound 3's estimate is 12-fold (1.08 log units) below it, and the stated range ends below it.
By their numbers in this assay, from the lowest: compound 2; then compounds 1 and 3 (each within the scatter of the next).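

In this assay, 3-cyanophenyl in place of 2-fluorophenyl on a carbonyl carbon gives a 19-fold higher number from compound 2 to compound 3 (1.27 log units; beyond the scatter). The read-out is therefore sensitive to this position, and a swap of one substituted phenyl for another can matter greatly here. Nothing available explains why the number rises.

This single step changes both the substituent and the number in its name, so the compounds shown cannot separate those two changes. A 2-cyanophenyl or 3-fluorophenyl group in this place would tell them apart.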